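The compounds below may be only part of what the source reports. "The series", "measured", "known", "first", "only" and "open" are said of these compounds alone.

Compound 1 `COc1cc(C(C)=O)ccc1OCCCN1CCC(C(N)(c2ccc(F)cc2)c2ccc(F)cc2)CC1` and compound 2 `COc1cc(C(C)=O)ccc1OCCCN1CCC(C(NC(C)=O)(c2ccc(F)cc2)c2ccc(F)cc2)CC1` share one core and differ in a single spot: acetyl in place of hydrogen on an amine nitrogen. In a functional assay (aorta) with Oryctolagus cuniculus as the target (a lower number here means tighter binding, a higher number weaker binding), compound 1 gives 31.6 nM, and compound 2 gives 63.1 nM, so this change made a 2.0-fold higher number from compound 1 to compound 2 (0.30 log units; within the scatter). Compound 3 `Nc1ccc(OCCCN2CCC(C(c3ccc(F)cc3)c3ccc(F)cc3)CC2)cc1` is built on a different core; how its core differs from that of compound 1 is not broken down here. In this assay compound 3 gives 31.6 nM, which lies level with compound 1 within the scatter. Compound 4 `CC(=O)Nc1ccc(OCCCN2CCC(C(c3ccc(F)cc3)c3ccc(F)cc3)CC2)cc1` has not been measured and differs from compound 3 by acetyl in place of hydrogen on a nitrogen on an aromatic ring. Among the compounds with values here, this is the same kind of change as the one seen between compound 1 and compound 2, but the place is not the same: there the new group sits on an amine nitrogen whose other neighbours are saturated chain carbon, here on a nitrogen on an aromatic ring whose other neighbours are aromatic carbon. For compound 4 the expected step is a 2.0-fold higher number from compound 3 to compound 4 (0.30 log units; within the scatter) because a change of this kind made a 2.0-fold higher number from compound 1 to compound 2 (0.30 log units; within the scatter) in the measured pair. In this assay compound 4 is therefore estimated at 63 nM, most likely between 25 nM and 160 nM.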

Compound 4, dissociation constant: 12.6 nM
The estimate for compound 4 lay 5.0-fold (0.70 log units) above the measured number; measured number below the stated range.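

Putting acetyl in place of hydrogen on a nitrogen on an aromatic ring gave a 2.5-fold lower number from compound 3 to compound 4 (0.40 log units; beyond the scatter) in this assay, so the direction seen for the same swap on an amine nitrogen did not carry over. Set side by side, the two results show that this change cannot simply be transferred from one core to the other in this series: the same change on two cores in this assay, a 2.0-fold higher number (0.30 log units; within the scatter) from compound 1 to compound 2 and a 2.5-fold lower number (0.40 log units; beyond the scatter) from compound 3 to compound 4, 5.0-fold (0.70 log units) apart, beyond the scatter of two such steps What this does not show is the source of the gap, as the two pairs differ both in their cores and in the kind of nitrogen that carries the acetyl, and each case rests on a single pair of compounds.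

The compounds shown leave open whether a longer acyl group such as propanoyl, or a methyl group, on the nitrogen of compound 3 would follow the result for acetyl. They also leave open whether a methanesulfonyl group there would give a step in the same direction, or whether the step belongs to acetyl alone.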